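The source may hold more compounds than are shown below. What is called first, only, known or untested is meant among the compounds shown, and "the series" means these compounds.

Measured so far:

Compound 1, `CC(C)C(=O)N(CC(=O)NCCN)c1ccc([N+](=O)[O-])c(C(F)(F)F)c1`, gives 18000 nM in a functional assay on K562 cells (Homo sapiens) for inhibition, read by MTT assay, with a stated time of 48 h; on this read-out higher numbers stand for weaker inhibition and lower numbers for stronger inhibition.
Compound 2, `CCCCCCCCCCCCOc1cc(OCCCCCCCCCCCC)cc(C(=O)OC)c1`, gives only a limit in this assay: > 1000000 nM.

Compound 2 therefore stands not at a number but at a limit; (the limit of > 1000000 nM in this assay, at which 1 of the 2 values shown sits). Going by the values given here, compound 1, built on a different core, shows a measured number, yet no single-change step connects it to compound 2, so the two values show only that one compound inhibits and the other does not within the tested range.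

Compound 3, `CCCCCCCCCCCCOc1cc(OCCCCCCCCCCCC)cc(C(=O)NCCN)c1`, differs from compound 2 in one place: (2-aminoethyl)amino in place of methoxy on a carbonyl carbon. Among the compounds with values here, no measured pair shares this change, so its expected size in this assay rests on no direct precedent. A step toward stronger inhibition is expected, of the size an at least 2.5-fold lower number from compound 2 to compound 3 (0.39 log units; beyond the scatter), though compound 3 may again reach only a limit. Compound 3 is estimated at 400000 nM, with a range from 40000 nM to 1000000 nM.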

Compound 3, half-maximal inhibitory concentration: > 1000000 nM
Compound 3 ended at the assay's limit; the forecaster's own chance of this, stated with the estimate: 50%; middle value at least 2.5-fold (0.39 log units) away from the limit.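

Compound 2 and compound 3 both end at a limit rather than a number, so the change from methoxy to (2-aminoethyl)amino has no readable size: the limit of > 1000000 nM in this assay, at which 2 of the 3 values shown sit.

As far as these compounds go, whether this change alters inhibition at all stays open, as does its effect on a compound with a measured value.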